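Working notes: halogenated phenyl variation at the ring nitrogen

A few compounds are considered here, and "the series" means these few. Any claim that something is new, unique, unknown or untested is made for them only; others in the source may bear on it.

Compounds measured so far in a functional assay on CHO cells with adenosine receptor A1 (Homo sapiens) as the target, read by cAMP accumulation and immunoassay, with a stated time of 6 min, tested at 10 uM; on this read-out lower numbers stand for a stronger effect and higher numbers for a weaker effect at the one concentration tested:
compound 1 `Nc1scc(CN2CCN(c3cc(Cl)cc(Cl)c3)CC2)c1C(=O)c1ccc(Cl)cc1` gives -74%
compound 2 `Nc1scc(CN2CCN(c3cccc4ccccc34)CC2)c1C(=O)c1ccc(Cl)cc1` gives -21%
compound 3 `Nc1scc(CN2CCN(c3cc(F)ccc3F)CC2)c1C(=O)c1ccc(Cl)cc1` gives -80%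

Compound 3 stands lowest of the three numbers. Its nearest neighbour is compound 1, the change being a number 6 percentage points lower from compound 1 to compound 3 (within the scatter). Its furthest neighbour is compound 2, the change being a number 59 percentage points lower from compound 2 to compound 3 (beyond the scatter). The one large move seen so far therefore sits with naphthalen-1-yl, and the two halogenated phenyl groups lie together.

The next compound is compound 4 `Nc1scc(CN2CCN(c3ccc(F)c(Cl)c3)CC2)c1C(=O)c1ccc(Cl)cc1`, whose structural change against compound 3 is 3-chloro-4-fluorophenyl in place of 2,5-difluorophenyl on an amine nitrogen in a ring. Among the compounds with values here, two measured steps bear on it: the change from compound 1 to compound 3 exchanged one dihalogenated phenyl for another and stayed within the scatter, while the change from compound 2 to compound 3 was large only where naphthalen-1-yl was involved. Compound 4 keeps a dihalogenated phenyl on the ring nitrogen, so no step beyond the scatter is expected in this assay, that is a number 4 percentage points higher from compound 3 to compound 4 (within the scatter). The expected value for compound 4 is therefore -76%, with a range from -92% to -58%.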

Compound 4, a percentage reported as activity, at one concentration (the size of the read-out at that concentration, not a potency): -78%
For compound 4 the middle estimate is 2 percentage points above the measured one; low and high end bracket the measured number.
By their numbers in this assay, from the lowest: compounds 3, 4 and 1 (each within the scatter of the next); then compound 2.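

With 3-chloro-4-fluorophenyl on the amine nitrogen in a ring, a phenyl carrying two different halogens joins the two earlier dihalogenated phenyl groups in this assay, with a number 2 percentage points higher from compound 3 to compound 4 (within the scatter) and a number 4 percentage points lower from compound 1 to compound 4 (within the scatter) both printed as within the scatter. The large gap to naphthalen-1-yl also holds for this third halogen pattern, at a number 57 percentage points lower from compound 2 to compound 4 (beyond the scatter), so among the four compounds only compound 2 stands apart. No measurement at hand accounts for this gap or for the closeness of the three dihalogenated phenyl groups.

The compounds shown leave open how a plain phenyl, or a phenyl bearing a methoxy or nitrile group, would read at this position. Also open, from the compounds shown here alone, is whether naphthalen-2-yl or a quinoline ring would read with compound 2 or with the dihalogenated phenyl compounds.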